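The source may hold more compounds than are shown below. What is called first, only, known or untested is meant among the compounds shown, and "the series" means these compounds.

Of the compounds shown here, three built on one shared core have been tested in a functional assay on HeLa cells (Homo sapiens) for antiproliferative activity, read by CCK-8 assay, with a stated time of 72 h, tested at 8 uM; a lower number here means a weaker effect, a higher number a stronger effect of the compound at the concentration tested. Compound 1 `Nc1ccccc1NC(=O)c1ccc(CSC(=S)N2CCN(C(c3ccccc3)c3ccccc3)CC2)cc1` gives 13.8%, compound 3 `Nc1ccccc1NC(=O)c1ccc(CSC(=S)N(Cc2ccccc2)Cc2ccccc2)cc1` gives 18.9%, and compound 2 `Nc1ccccc1NC(=O)c1ccc(CSC(=S)N2CCCc3ccccc32)cc1` gives 35.7%. Compound 2 stands highest of the three: its nearest neighbour is compound 3, lower by a gap beyond the usual scatter, and the furthest is compound 1, lower by a still wider gap. Compound 4 `CN1CCN(C(=S)SCc2ccc(C(=O)Nc3ccccc3N)cc2)CC1` has not yet been measured; it differs from compound 2 by 4-methylpiperazin-1-yl in place of 1,2,3,4-tetrahydroquinolin-1-yl on a thiocarbonyl carbon. A downward step is expected, probably beyond the scatter, because compound 1 gives 13.8% and compound 3 gives 18.9% with other groups in that place. Compound 4 is therefore expected to give about 20%, within 6% to 36%. This estimate means a step of a number 15.7 percentage points lower from compound 2 to compound 4 (beyond the scatter) in this assay.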

Compound 4, a percentage reported as inhibition, at one concentration (the size of the read-out at that concentration, not a potency): 75.7%
Estimate against measurement, compound 4: 55.7 percentage points below; measured number above the stated range.
By their numbers in this assay, from the lowest: compounds 1 and 3 (each within the scatter of the next); then compound 2; then compound 4.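

In this assay, the group on the thiocarbonyl carbon proves able to change the read-out sharply: 4-methylpiperazin-1-yl in place of 1,2,3,4-tetrahydroquinolin-1-yl gives a number 40 percentage points higher from compound 2 to compound 4 (beyond the scatter) at this position. The change removes an aromatic ring and adds a hydrogen-bond acceptor, but these compounds cannot show which of the two matters. No measurement shown here accounts for the rise. As far as these compounds go, whether the methyl group is needed remains open, since an unsubstituted piperazin-1-yl would test this. A morpholin-4-yl or dimethylamino group could show whether the second ring nitrogen matters.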